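Working notes on the terminal ring exchange

The source may report more compounds than this note shows. Statements on the series, on what has been measured and on what is new or still open speak of the compounds shown alone.

Compound 2 `CCOC(=O)CCCCCOc1cccc(CN(C(=O)c2ccc(-c3cc(OC)ccc3F)cc2)C(C)C)c1` stands only at a limit in an ADME assay on HepG2 cells (Homo sapiens) for cytotoxicity, read by CellTiter-Glo and resazurin assay, with a stated time of 72 h; a lower number here means that less compound is needed, a higher number that more compound is needed for the effect: compound 2 gives > 26000 nM, which is a limit of the assay and not a number. Compound 1 `CCOC(=O)CCCCCOc1cccc(CN(C(=O)c2ccc(-c3cccc(OC(F)(F)F)c3)cc2)C(C)C)c1` likewise gives only a limit, > 26000 nM. The step that the two limits leave unreadable from compound 1 to compound 2 is therefore unreadable, both results sitting at the limit of > 26000 nM in this assay, at which 2 of the 2 values shown sit. Compound 3 `CCOC(=O)CCCCCOc1cccc(CN(C(=O)c2ccc(-c3cccc(F)c3)cc2)C(C)C)c1` carries 3-fluorophenyl in place of 2-fluoro-5-methoxyphenyl on an aromatic carbon. Only the unreadable step from compound 1 to compound 2 bears on this change, so no step beyond the scatter is expected in this assay. For compound 3 the value in this assay is estimated at 40000 nM, range 20000 nM to 100000 nM. The expected step that the limit leaves unreadable from compound 2 to compound 3 is estimated to lie within the scatter.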

Compound 3, half-maximal effective concentration: > 26000 nM
Compound 3 gave a limit, no number (the forecaster's own chance of this, stated with the estimate: 80%); the middle value is on the limit's open side.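

In this assay compound 3 gives > 26000 nM, a limit of the assay and not a number. No step linking compound 1, compound 2 and compound 3 can be read: the limit of > 26000 nM in this assay, at which 3 of the 3 values shown sit.

As far as these compounds go, how far past this limit each of the three compounds lies remains open.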